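Swapping a piperidine for a tolyl group: solubility outlook

This account rests on a few compounds, and the source may have more. Where it says the series, first, only, none or still open, it means among the compounds named here.

Two compounds have been measured in a physicochemical assay for solubility, in phosphate buffer, at pH 7.4; a lower number here means a less soluble compound, a higher number a more soluble compound:
Compound 1, `OCC1CCN(c2nccnc2OC2CN(c3cnc4ccccc4n3)C2)CC1`, gives 500000 nM.
Compound 2, `c1ccc2nc(N3CC(Oc4nccnc4N4CCCCC4)C3)ccc2c1`, gives < 1000 nM.

For compound 2 this value is a limit of the assay and not a measured number. Compound 2 therefore stands at the limit of < 1000 nM in this assay, at which 1 of the 2 values shown sits, and only that limit is known for it.

Compound 3, `Cc1ccc(-c2nccnc2OC2CN(c3ccc4ccccc4n3)C2)cc1`, has not yet been measured. It differs from compound 2 in one place: 4-methylphenyl in place of piperidin-1-yl on an aromatic carbon. For the measured compounds named here, no step between two measured compounds is available here, so the size of the change must be guessed from the structures alone. The step that the limit leaves unreadable from compound 2 to compound 3 is expected to be downward or within the scatter, and not upward. Compound 3 is expected to give about 400 nM, in the range 50 nM to 2000 nM, and most likely to be reported again only as a limit.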

Compound 3, solubility: < 1000 nM
Compound 3 ended at the assay's limit; the forecaster's own chance of this, stated with the estimate: 80%; the middle value is on the limit's open side.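

No step can be read between compound 2 and compound 3 in this assay, because each is reported only at the same limit: the limit of < 1000 nM in this assay, at which 2 of the 3 values shown sit.

The compounds shown leave open whether 4-methylphenyl in place of piperidin-1-yl changes solubility at all, and by how much.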